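Dicyclopropylmethylamino Replaces a Tertiary Amine on a Pyrazine-Type Core

The source may report more compounds than this note shows. Statements on the series, on what has been measured and on what is new or still open speak of the compounds shown alone.

Compound 1, `CCCN(CC1CC1)c1nc(CC)c(-c2ccc(Cl)cc2Cl)nc1CC`, is one of three compounds examined in an assay on IMR-32 cells for displacement of a labelled ligand from corticotropin-releasing factor receptor 1 (Homo sapiens), read by scintillation counting, with a stated time of 2 h (a lower number here means a stronger inhibitor, a higher number a weaker inhibitor), where compound 1 gives 19.2 nM. This is the highest of the three numbers. Compound 2, `CCc1nc(-c2ccc(OC)nc2OC)c(CC)nc1NC(CC)CC`, gives 11.6 nM in this assay, a gap to compound 1 that lies within the usual scatter, so no order between the two can be claimed. Compound 3, `CCc1nc(-c2ccc(OC(F)(F)F)cc2OC)c(OC)nc1NC(CC)CC`, gives 6.1 nM in this assay, and here the gap to compound 1 lies beyond the scatter. Compounds 2 and 3 each differ from compound 1 in several places at once, so no single change can be read from them.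

Compound 4, `CCc1nc(-c2ccc(Cl)cc2Cl)c(CC)nc1NC(C1CC1)C1CC1`, differs from compound 1 in one place: (dicyclopropylmethyl)amino in place of (cyclopropylmethyl)(propyl)amino on an aromatic carbon. Going by the values given here, no measured pair shows the effect of this change on its own. The author therefore expects a step from compound 1 to compound 4 of a 1.9-fold lower number from compound 1 to compound 4 (0.28 log units; within the scatter), toward a lower number but not clearly beyond the scatter. The estimate for compound 4 in this assay is 10 nM, with a range from 3 nM to 35 nM.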

Compound 4, inhibition constant: 3.7 nM
Compound 4: the middle estimate sits 2.7-fold (0.43 log units) above what was measured; low and high end bracket the measured number.
By their numbers in this assay, from the lowest: compounds 4, 3, 2 and 1 (each within the scatter of the next, the first and the last beyond it).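

In this assay, going by these compounds alone, placing (dicyclopropylmethyl)amino in place of (cyclopropylmethyl)(propyl)amino on this aromatic carbon gives a 5.2-fold lower number from compound 1 to compound 4 (0.72 log units; beyond the scatter), the first single change in the set that can be read on its own. The entering group has the same count of heavy atoms as the leaving one, but it carries a second three-membered ring and a hydrogen-bond donor, so this position accepts a secondary amine in place of a tertiary one with no loss of inhibition. No measurement here explains the step, and this one pair cannot separate the second ring from the donor.

On these data alone, whether a similar step holds with other aryl groups, such as the methoxy-substituted ones of compounds 2 and 3, remains open. Also open, as far as these compounds go, is what a methyl group on the nitrogen of (dicyclopropylmethyl)amino would do.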